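Swapping the end group of compound 3

The source may report more compounds than this note shows. Statements on the series, on what has been measured and on what is new or still open speak of the compounds shown alone.

In an ADME assay on Karpas-1106P cells (Homo sapiens) for cytotoxicity (on this read-out lower numbers stand for an effect already at smaller amounts and higher numbers for an effect only at larger amounts of compound), compound 1 `COc1cccc(C(=O)NCCNC(=O)[C@H](CC(=O)NC(C)(C)C)NS(=O)(=O)c2ccc(C)cc2)c1` gives > 11100 nM as a limit, not a number. Compound 2 `Cc1ccc(S(=O)(=O)N[C@@H](CC(=O)NC(C)(C)C)C(=O)NCCNC(=O)c2ccccc2Cl)cc1` gives > 11100 nM as a limit too. Compound 3 `COc1cc(OC)cc(C(=O)NCCNC(=O)[C@H](CC(=O)NC(C)(C)C)NS(=O)(=O)c2ccc(C)cc2)c1` likewise stands at > 11100 nM as a limit and not a number. Among the measured compounds shown here, the series so far shows the limit of > 11100 nM in this assay, at which 3 of the 3 values shown sit, and nothing more. Compound 4 `Cc1ccc(S(=O)(=O)N[C@@H](CC(=O)NC(C)(C)C)C(=O)NCCNS(=O)(=O)c2ccccc2)cc1` has phenylsulfonyl in place of (3,5-dimethoxyphenyl)carbonyl on an amine nitrogen, and phenylsulfonyl in place of (3,5-dimethoxyphenyl)carbonyl on an amine nitrogen counts that change. The closest measured changes are a step that the two limits leave unreadable from compound 1 to compound 3 and a step that the two limits leave unreadable from compound 2 to compound 3 and they give no size. So in this assay no step beyond the scatter is expected, and no direction. This estimate means a step that the limit leaves unreadable from compound 3 to compound 4 as the expected step. Compound 4 is estimated at 14000 nM with an expected range from 6000 nM to 30000 nM and will probably also report only a limit.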

Compound 4, half-maximal effective concentration: > 11100 nM
Compound 4 was reported as a limit (the forecaster's own chance of this, stated with the estimate: 85%); the middle value is on the limit's open side.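

Compound 4 gives only a limit, as do compound 1, compound 2 and compound 3, so no step among them can be read: the limit of > 11100 nM in this assay, at which 4 of the 4 values shown sit.

Going by these compounds, whether changing the end group shifts this read-out at all remains open.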